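From thiophene back to a substituted phenyl imine

A few compounds are considered here, and "the series" means these few. Any claim that something is new, unique, unknown or untested is made for them only; others in the source may bear on it.

Compound 1, `CN1CCN(c2ccc(Nc3ncc(/N=C/c4ccccc4)c(NC4CCCC4)n3)cc2)CC1`: in a functional assay on MCF7 cells (Homo sapiens) for antiproliferative activity, read by MTT assay (on this read-out lower numbers stand for stronger inhibition and higher numbers for weaker inhibition), compound 1 reaches only a limit, > 100000 nM.
Compound 2, `CN1CCN(c2ccc(Nc3ncc(/N=C/c4cccs4)c(NC4CCCC4)n3)cc2)CC1`: in this assay compound 2 gives 33900 nM.
Compound 3, `CN1CCN(c2ccc(Nc3ncc(/N=C/c4ccc(C(F)(F)F)cc4)c(NC4CCCC4)n3)cc2)CC1`: not yet measured.

Among the compounds with values here, compound 2 holds the only actual number in this assay; the other value is a limit, (the limit of > 100000 nM in this assay, at which 1 of the 2 values shown sits), so compound 2 cannot be ranked against anything except that limit. Within the data shown here, the single measured step is an at least 2.9-fold lower number from compound 1 to compound 2 (0.46 log units; beyond the scatter), in which thiophen-2-yl replaced phenyl on the carbon with a double bond to nitrogen. The change now in view, (4-(trifluoromethyl)phenyl in place of thiophen-2-yl on a carbon with a double bond to nitrogen), runs the other way: it gives up the five-membered ring and brings back a six-membered ring of carbon only, as in compound 1, now carrying a trifluoromethyl group. Among the measured compounds shown here, the step from compound 1 to compound 2 is the only guide, and it points toward a higher number for compound 3, possibly back at the limit. Compound 3 is therefore expected to lie around 80000 nM, within 25000 nM to 300000 nM, a step of a 2.4-fold higher number from compound 2 to compound 3 (0.37 log units; beyond the scatter) that is expected to be beyond the scatter.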

Compound 3, half-maximal inhibitory concentration: > 100000 nM
Compound 3: a limit, no number (the forecaster's own chance of this, stated with the estimate: 45%); middle value at least 1.2-fold (0.09 log units) from the limit.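

Moving from thiophen-2-yl to 4-(trifluoromethyl)phenyl on the carbon with a double bond to nitrogen gives an at least 2.9-fold higher number from compound 2 to compound 3 (0.46 log units; beyond the scatter), so the readable number in this assay is lost once more. Among the compounds shown, both groups built on a six-membered aromatic ring of carbon only end at a limit, with or without trifluoromethyl, while compound 2, with its five-membered ring holding sulfur, is the one exception and the only compound with a readable value. The step from compound 1 to compound 3, with trifluoromethyl in place of hydrogen on an aromatic carbon, cannot be read, because both values are limits and the trifluoromethyl group's effect, if any, lies out of view: the limit of > 100000 nM in this assay, at which 2 of the 3 values shown sit.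

As far as these compounds go, whether the sulfur atom matters, or simply the five-membered ring, stays open, and furan-2-yl or pyrrol-2-yl at this carbon would separate the two. From the compounds shown here alone, it is also open whether any six-membered ring can give a readable value here, for instance a phenyl ring carrying a hydroxyl or an amine, or a pyridin-2-yl ring.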